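The source may report more compounds than this note shows. Statements on the series, on what has been measured and on what is new or still open speak of the compounds shown alone.

Compound 1 `CS(=O)(=O)Oc1c(C(=O)NCc2ccc(F)cc2)nc(Br)c2cccnc12` — in a functional assay on HCT-116 cells (Homo sapiens) for cytotoxicity, read by MTT assay, with a stated time of 72 h (on this read-out lower numbers stand for stronger inhibition and higher numbers for weaker inhibition), compound 1 gives > 20000 nM, which is a limit of the assay rather than a number.
Compound 2 `C[C@H](Nc1c(C(=O)NCc2ccc(F)cc2)nc(Br)c2cccnc12)c1ccccc1` — in this assay compound 2 gives > 20000 nM, again a limit and not a number.
Compound 3 `Cc1ccc(S(=O)(=O)Oc2c(C(=O)NCc3ccc(F)cc3)nc(Br)c3cccnc23)cc1` — in this assay compound 3 gives > 20000 nM, likewise a limit only.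

Compound 1 thus stands at the limit of this assay, and the same is true of every other value shown (the limit of > 20000 nM in this assay, at which 3 of the 3 values shown sit). The steps among the measured compounds are therefore not readable: a step that the two limits leave unreadable from compound 1 to compound 2, a step that the two limits leave unreadable from compound 1 to compound 3 and a step that the two limits leave unreadable from compound 2 to compound 3 all run from one limit to another. Compound 4 `COC(=O)CNc1c(C(=O)NCc2ccc(F)cc2)nc(Br)c2cccnc12` differs from compound 1 by ((methoxycarbonyl)methyl)amino in place of (methylsulfonyl)oxy on an aromatic carbon. For the measured compounds named here, the steps that bear on this change, from compound 1 to compound 2 and from compound 1 to compound 3, both start at the same limit as compound 1 and end at a limit, so they give no readable size and no direction. With three compounds all sitting at the limit (the limit of > 20000 nM in this assay, at which 3 of the 3 values shown sit), the expectation for compound 4 is that it too shows no measurable cytotoxicity, the expected step being a step that the limit leaves unreadable from compound 1 to compound 4. Compound 4 is therefore estimated at 30000 nM in this assay, within a range of 8000 nM to 100000 nM.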

Compound 4, half-maximal inhibitory concentration: > 10000 nM
Compound 4 gave a limit, no number (the forecaster's own chance of this, stated with the estimate: 80%); the middle value does not contradict the limit.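

In this assay compound 4 gives > 10000 nM, again a limit and not a number. Its steps from compound 1, compound 2 and compound 3 all join two limits, and none can be read. The compounds shown leave open whether any group on this aromatic carbon gives a measurable value.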